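Bromo in place of iodo on the shared core

The source may hold more compounds than are shown below. What is called first, only, known or untested is meant among the compounds shown, and "the series" means these compounds.

Measured so far:
compound 1, `O=C1C=C(Nc2ccc(I)cc2)C(=O)c2c1nc1n2[C@H]2OC[C@@H](O)[C@H]2OC1`: in a functional assay on ECa-109 cells for inhibition, with ECa-109 cell line (Homo sapiens) as the target, read by sulforhodamine B assay (on this read-out higher numbers stand for weaker inhibition and lower numbers for stronger inhibition), compound 1 gives 2300 nM.
compound 2, `O=C1C(NCc2ccccc2)=CC(=O)c2c1nc1n2[C@H]2OC[C@@H](O)[C@H]2OC1`: for compound 2 this assay reports only a limit, > 8000 nM.

For the measured compounds named here, compound 1 holds the only definite number in this assay. Going by the values given here, the other value shown is a limit and no number: of the two values, one sits at the limit of > 8000 nM in this assay, at which 1 of the 2 values shown sits, so no measured step can be drawn between compound 1 and compound 2, and nothing is said of their order.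

Compound 3, `O=C1C=C(Nc2ccc(Br)cc2)C(=O)c2c1nc1n2[C@H]2OC[C@@H](O)[C@H]2OC1`, has not been measured. It differs from compound 1 in one place: bromo in place of iodo on an aromatic carbon.

Among the compounds with values here, no step between measured compounds is available to set the size of this change. The expectation is a small step from compound 1 to compound 3, a 1.3-fold higher number from compound 1 to compound 3 (0.12 log units; within the scatter), in the direction of weaker inhibition or none beyond the usual scatter. Compound 3 is estimated at 3000 nM, with a range from 1200 nM to 7500 nM; a reported limit instead of a number is judged unlikely but not excluded.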

Compound 3, half-maximal inhibitory concentration: 2850 nM
The estimate for compound 3 lay 1.1-fold (0.02 log units) above the measured number, and the stated range covers the measured number.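

In this assay, for the compounds shown here, 4-bromophenyl in place of 4-iodophenyl gives a 1.2-fold higher number from compound 1 to compound 3 (0.09 log units; within the scatter), the first step that can be read between two definite numbers. On this aromatic carbon, para to a large group, the assay therefore does not tell bromo and iodo apart, and the (4-bromophenyl)amino and (4-iodophenyl)amino compounds can be treated as one point for now. Nothing measured here bears on why the exchange of one halogen for the other leaves no step beyond the scatter.

Going by these compounds alone, for compound 2 the assay gives only the limit > 8000 nM and no step links it to compound 1 or compound 3. Open, on these data alone, is whether this carbon tolerates more than a swap between two halogens: a hydrogen, a fluoro, a methoxy, an amine or a carboxylic acid in the same place could show whether the group matters here at all, or whether the number is set elsewhere on the shared core.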